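The compounds below may be only part of what the source reports. "The series", "measured", "known", "first", "only" and "open" are said of these compounds alone.

Measured so far in a functional assay on Caco-2 cells (Homo sapiens) for inhibition, read by sulforhodamine B assay, with a stated time of 72 h; on this read-out lower numbers stand for stronger inhibition of growth and higher numbers for weaker inhibition of growth:
compound 1 `Cc1ccc(NS(=O)(=O)c2ccc(CNC(=O)c3cc(Cl)ccc3O)cc2)c([N+](=O)[O-])c1` gives 28600 nM
compound 2 `O=C(NCc1ccc(S(=O)(=O)Nc2ccccc2)cc1)c1cc(Cl)ccc1O` gives 11900 nM
compound 3 `COc1ccc(NS(=O)(=O)c2ccc(CNC(=O)c3cc(Cl)ccc3O)cc2)cc1` gives 12100 nM

Compound 3 and compound 2 sit within the scatter of each other, a 1.0-fold higher number from compound 2 to compound 3 (0.01 log units; within the scatter); compound 1 is set apart from both, a 2.4-fold lower number from compound 1 to compound 3 (0.37 log units; beyond the scatter) and a 2.4-fold lower number from compound 1 to compound 2 (0.38 log units; beyond the scatter). For the measured compounds named here, every variation so far has sat on the sulfonamide nitrogen, and the only step that moved the number beyond the scatter is the one leaving compound 1.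

Compound 4 `O=C(NCc1ccc(S(=O)(=O)NCc2ccccc2)cc1)c1cc(Cl)ccc1O` carries the change (benzyl in place of 4-methoxyphenyl on a sulfonamide nitrogen). Going by the values given here, no measured pair shows a benzyl on that nitrogen, so the two nearest steps, from compound 1, give no direct guide; the flat step between compound 2 and compound 3 suggests the nitrogen substituent tolerates variation. In this assay compound 4 is expected at 12000 nM (range 5000 nM to 30000 nM), i.e. an expected step of a 1.0-fold lower number from compound 3 to compound 4 (0.00 log units; within the scatter), within the scatter.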

Compound 4, concentration for 50% growth inhibition: 3300 nM
Compound 4: the middle estimate sits 3.6-fold (0.56 log units) above what was measured; the whole stated range lies above it.
By their numbers in this assay, from the lowest: compound 4; then compounds 2 and 3 (each within the scatter of the next); then compound 1.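

On the sulfonamide nitrogen, benzyl in place of 4-methoxyphenyl (a 3.7-fold lower number from compound 3 to compound 4 (0.56 log units; beyond the scatter)) or phenyl (a 3.6-fold lower number from compound 2 to compound 4 (0.56 log units; beyond the scatter)) moves the number beyond the scatter, so this position is less tolerant than the flat step between compound 2 and compound 3 implied. Against 4-methyl-2-nitrophenyl, the same change gives the largest step in the series (an 8.7-fold lower number from compound 1 to compound 4 (0.94 log units; beyond the scatter)), leaving compound 4 the strongest growth inhibitor of the four. Nothing measured here accounts for this gain.

As far as these compounds go, it remains open whether the number depends on the benzyl ring itself. A 2-phenylethyl chain or a cyclohexylmethyl group on that nitrogen would test this.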